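Pyrazole carboxamides: dropping a methyl on the way to compound 4

This account rests on a few compounds, and the source may have more. Where it says the series, first, only, none or still open, it means among the compounds named here.

Compound 1, `N#Cc1cnn(C(=O)NCc2ccc(OCc3ccccc3)cc2)c1`: 60 nM
Compound 2, `Cc1cnn(C(=O)N2CCCCC2)c1`: 2200 nM
Compound 3, `Cc1cnn(C(=O)N2CCCN(Cc3ccc(OCc4ccccc4)cc3)CC2)c1`: 560 nM

Of the compounds shown here, three have been measured in an assay on membranes from brain for binding affinity to Fatty-acid amide hydrolase 1 (Mus musculus), read by fluorescence, with stated times of 1 h and 30 min; on this read-out lower numbers stand for stronger inhibition and higher numbers for weaker inhibition. Compound 3, `Cc1cnn(C(=O)N2CCCN(Cc3ccc(OCc4ccccc4)cc3)CC2)c1`, gives 560 nM and stands second highest of the three numbers. Its nearest neighbour is compound 2, whose number is higher, a gap beyond the usual scatter; furthest from it lies compound 1, whose number is lower, again beyond the scatter. No two of these compounds differ in one place only, so no single step can be read from them.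

Compound 4, `O=C(N1CCCN(Cc2ccc(OCc3ccccc3)cc2)CC1)n1cccn1`, has not yet been measured. It differs from compound 3 by hydrogen in place of methyl on an aromatic carbon, or, read one bond further out, 4-methyl-1H-pyrazol-1-yl to 1H-pyrazol-1-yl. For the measured compounds named here, nothing among the measured compounds isolates this change, so the step is expected to be small, most likely within the scatter, with a slight lean towards a higher number. The expected step from compound 3 to compound 4 is a 1.3-fold higher number from compound 3 to compound 4 (0.13 log units; within the scatter). For compound 4 the estimate in this assay is 750 nM, with a range from 250 nM to 2200 nM.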

Compound 4, half-maximal inhibitory concentration: 450 nM
The estimate for compound 4 lay 1.7-fold (0.22 log units) above the measured number, within the range that was stated.
By their numbers in this assay, from the lowest: compound 1; then compounds 4 and 3 (each within the scatter of the next); then compound 2.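

In this assay, taking the methyl off gives a 1.2-fold lower number from compound 3 to compound 4 (0.09 log units; within the scatter), the first change in a single place that can be read among these compounds. At this aromatic carbon, then, 4-methyl-1H-pyrazol-1-yl and 1H-pyrazol-1-yl are not told apart by the read-out, and the methyl is not needed to hold the inhibition at this level in this pair. Nothing available offers an explanation for this result.

The compounds shown leave open whether an ethyl group, a chlorine atom or an amine on the same carbon would shift the number beyond the scatter. They also leave open whether a nitrile there, the group carried by compound 1, would do so with the rest of compound 4 unchanged.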